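Replacing the Dichlorophenylamino Arm of Compound 3

This account rests on a few compounds, and the source may have more. Where it says the series, first, only, none or still open, it means among the compounds named here.

Of the compounds shown here, three have been measured in a functional assay on 786-0 cells (Homo sapiens) for inhibition, read by sulforhodamine B assay, with a stated time of 48 h, tested at 0.01 uM; on this read-out lower numbers stand for a stronger effect and higher numbers for a weaker effect at the one concentration tested. Compound 1 `O=C(Nc1cccc(-n2cc(-c3ccncc3)c(-c3cc(O)cc(Cl)c3)n2)c1)Nc1ccc(Cl)c(Cl)c1` gives 92%, compound 2 `COc1cc(Cl)cc(-c2nn(-c3cccc(NC(=O)Nc4cc(C(F)(F)F)cc(C(F)(F)F)c4)c3)cc2-c2ccncc2)c1` gives 96%, and compound 3 `COc1cc(Cl)cc(-c2nn(-c3cccc(NC(=O)Nc4ccc(Cl)c(Cl)c4)c3)cc2-c2ccncc2)c1` gives 100%. On these numbers compound 3 has the highest reading of the three, with compound 2 nearest and compound 1 furthest, but both gaps lie within the scatter, so the three compounds read alike and none can be called more or less active than another. Within the data shown here, the only measured step that changes a single place, a number 8 percentage points higher from compound 1 to compound 3 (within the scatter), comes from methyl in place of hydrogen on an oxygen on an aromatic ring, and it too stays within the scatter.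

Compound 4 `COc1cc(Cl)cc(-c2nn(-c3cccc(NC(=O)c4cccc(C(F)(F)F)c4)c3)cc2-c2ccncc2)c1` has not yet been measured in this assay. Among the measured compounds shown here, it differs from compound 3 in one place: 3-(trifluoromethyl)phenyl in place of (3,4-dichlorophenyl)amino on a carbonyl carbon No measured step concerns this part of the molecule, so nothing measured bears directly on the change; the one step that exists sits elsewhere and was small. With all three numbers gathered at the weak end of the read-out, the step of a number 3 percentage points lower from compound 3 to compound 4 (within the scatter) is expected to be no larger than the scatter. Compound 4 is therefore expected to give about 97%, with four of five repeats expected between 85% and 106%.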

Compound 4, a percentage reported as activity, at one concentration (the size of the read-out at that concentration, not a potency): 99%
The estimate for compound 4 lay 2 percentage points below the measured number, and the stated range covers the measured number.
By their numbers in this assay, from the lowest: compounds 1, 2, 4 and 3 (each within the scatter of the next).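

Among these compounds, the step in this assay reads a number 1 percentage points lower from compound 3 to compound 4 (within the scatter), so this is the first measured change at this part of the molecule, and compound 3 and compound 4 read alike with (3,4-dichlorophenyl)amino or 3-(trifluoromethyl)phenyl on the carbonyl carbon. Among the compounds shown here, the hydrogen-bond donor counted on the leaving group has no counterpart on the entering group, and this difference comes with no separation of the two readings beyond the scatter, so at this one concentration the read-out does not depend on that donor or on the amino link in these two compounds. No measurement at hand offers an explanation for the two compounds reading alike.

All four readings lie at the weak end of the read-out, so these compounds leave open whether the exchange would matter at a concentration where the series gives a clearly lower number. On these data alone, it also remains open whether a different group on the same carbonyl carbon, such as a simple amine, a carboxylic acid or a longer alkyl chain, would separate from compound 3 beyond the scatter.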